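Alkyl chain homologue in the furanylmethyl diamine series

A few compounds are considered here, and "the series" means these few. Any claim that something is new, unique, unknown or untested is made for them only; others in the source may bear on it.

Compound 2 `CN(C)c1cccc(Oc2ccc3c(NCCCNCc4ccco4)ccnc3c2)c1` carries 3-(dimethylamino)phenoxy on the shared core. For the measured compounds named here, in a physicochemical assay for acid dissociation, compound 2 gives 9.28, and the only other measured member, compound 1 `CC(C)Cc1ccc2c(NCCCNCc3ccco3)ccnc2c1` with isobutyl at that carbon, gives 9.47; the two numbers lie within the scatter of one another, so compound 2 stands alongside compound 1 rather than apart from it. Compound 3 `CC(C)CCc1ccc2c(NCCCNCc3ccco3)ccnc2c1` is the next member: isopentyl in place of 3-(dimethylamino)phenoxy on an aromatic carbon. Going by the values given here, the one step measured so far, a number 0.19 log units lower from compound 1 to compound 2 (within the scatter), bears on this change directly, since it swaps the same two kinds of substituent in the opposite direction and stayed within the scatter. Isopentyl and isobutyl differ only by chain length, so compound 3 is expected to sit close to compound 1, with a step of a number 0.17 log units higher from compound 2 to compound 3 (within the scatter) that should itself fall within the scatter. Compound 3 is accordingly estimated at 9.45, expected to fall between 9.15 and 9.75.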

Compound 3, acid dissociation constant: 9.47
The estimate for compound 3 lay 0.02 log units below the measured number; the measured number falls inside the stated range.
By their numbers in this assay, from the lowest: compounds 2, 1 and 3 (each within the scatter of the next).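

In this assay the reverse swap gives a number 0.19 log units higher from compound 2 to compound 3 (within the scatter) with isopentyl entering, so exchange between 3-(dimethylamino)phenoxy and an alkyl group at this carbon now reads within the scatter in both directions, across two different alkyl groups. The chain change gives a separate reading, with no change at the digits printed from compound 1 to compound 3 (within the scatter) for isopentyl against isobutyl, so these two alkyl groups cannot be told apart in this assay at this carbon. Nothing on hand explains why these substituents leave the number within the scatter.

Open, going by these compounds, is whether a carboxylic acid or a much longer chain at this carbon would move the number beyond the scatter. Also open, on these data alone, is whether this reading holds when the furanylmethyl diamine chain itself is changed, for example with a piperidine in place of the furan.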